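Thiophene to Furan on the Oxo Core: Compound 3 to Compound 4

The source may report more compounds than this note shows. Statements on the series, on what has been measured and on what is new or still open speak of the compounds shown alone.

Measured so far:
Compound 1 `O=c1[nH]cnc2c1c(-c1cc3ccccc3o1)cn2[C@@H]1O[C@H](CO)[C@@H](O)[C@H]1O` gives the limit > 20000 nM.
Compound 2 `COc1ncnc2c1c(-c1ccco1)cn2[C@@H]1O[C@H](CO)[C@@H](O)[C@H]1O` gives 40 nM.
Compound 3 `O=c1[nH]cnc2c1c(-c1cccs1)cn2[C@@H]1O[C@H](CO)[C@@H](O)[C@H]1O` gives the limit > 20000 nM.

For the measured compounds named here, in a functional assay on HCT-116 cells (Homo sapiens), read by MTT assay, with a stated time of 72 h (a higher number here means a weaker inhibitor, a lower number a stronger inhibitor), compound 3 sits at the limit, a value it shares with compound 1 according to the limit of > 20000 nM in this assay, at which 2 of the 3 values shown sit, so the one measured step, a step that the two limits leave unreadable from compound 1 to compound 3, is unreadable. Compound 4 `O=c1[nH]cnc2c1c(-c1ccco1)cn2[C@@H]1O[C@H](CO)[C@@H](O)[C@H]1O` differs from compound 3 by furan-2-yl in place of thiophen-2-yl on an aromatic carbon. Going by the values given here, no readable step covers this change; the only recorded step gives no size. Compound 2 carries furan-2-yl on a different core and gives a numeric value in this assay. Because both compounds on the oxo core sit at the limit of > 20000 nM in this assay, at which 2 of the 3 values shown sit, compound 4 is expected to stay near that limit, so the expected step is a step that the limit leaves unreadable from compound 3 to compound 4. Compound 4 is estimated at 25000 nM, within 4000 nM to 100000 nM.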

Compound 4, half-maximal inhibitory concentration: > 20000 nM
Compound 4 ended at the assay's limit; the forecaster's own chance of this, stated with the estimate: 70%; the middle value lies beyond the limit too.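

No new step can be read among compound 1, compound 3 and compound 4, which all rest at the same limit in this assay: the limit of > 20000 nM in this assay, at which 3 of the 4 values shown sit.

The compounds shown leave open whether 1-benzofuran-2-yl, thiophen-2-yl and furan-2-yl differ at all on their shared core.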